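Solubility across the furanylmethyl and hydroxymethoxybenzyl amine pair

This account rests on a few compounds, and the source may have more. Where it says the series, first, only, none or still open, it means among the compounds named here.

Three compounds of the series carry a measured value in a physicochemical assay for solubility, with a stated time of 18 h, at pH 7.4; on this read-out higher numbers stand for higher solubility and lower numbers for lower solubility. Compound 1 `Cc1cc(C)cc(Cc2ccc3c(NCCCNCc4ccco4)ccnc3c2)c1` gives 4200 nM. Compound 2 `COc1cccc(CNCCCNc2ccnc3cc(Cc4cc(C)cc(C)c4)ccc23)c1O` gives 4200 nM. Compound 3 `FC(F)(F)c1cc(-c2ccc3c(NCCCNCc4ccco4)ccnc3c2)cc(C(F)(F)F)c1` gives 32000 nM, the highest number of the three; its values against compound 1 and against compound 2 both lie beyond the scatter, so compound 3 stands apart on this read-out.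

Among the measured compounds shown here, the only single-place step measured so far runs from compound 1 to compound 2: 2-hydroxy-3-methoxyphenyl in place of furan-2-yl on a saturated chain carbon bound to an amine nitrogen. On this assay it made no change at the digits printed from compound 1 to compound 2 (within the scatter).

Compound 3 and compound 1 share the chain and the amine but carry different cores; the difference between the two cores is not broken down here.

Compound 4 `COc1cccc(CNCCCNc2ccnc3cc(-c4cc(C(F)(F)F)cc(C(F)(F)F)c4)ccc23)c1O` is not yet measured. It relates to compound 3 in the same way as compound 2 relates to compound 1: 2-hydroxy-3-methoxyphenyl in place of furan-2-yl on a saturated chain carbon bound to an amine nitrogen. The place of the change is the same in both pairs, so this is the same change made on the core of compound 3 rather than on the core of compound 1.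

The step from compound 3 to compound 4 is expected to be no change at the digits printed from compound 3 to compound 4 (within the scatter), an expectation that rests on compound 1 and compound 2, where the same change gave no change at the digits printed from compound 1 to compound 2 (within the scatter). On that basis compound 4 is estimated at 32000 nM, with a likely range from 14000 nM to 70000 nM on this assay.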

Compound 4, solubility: 32000 nM
Compound 4: the middle estimate sits on the measured number at the digits printed; low and high end bracket the measured number.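

In this assay, 2-hydroxy-3-methoxyphenyl in place of furan-2-yl on a saturated chain carbon bound to an amine nitrogen gave no change at the digits printed from compound 3 to compound 4 (within the scatter), and the same change on the other core gave no change at the digits printed from compound 1 to compound 2 (within the scatter), so in both pairs shown the exchange leaves the read-out within the scatter. This shows that the change carried from the core of compound 1 to the core of compound 3 with the same outcome, even though compound 3 and compound 4 stand at a different level of the read-out from compound 1 and compound 2; it rests on two pairs only and does not establish a rule for other cores in the series. Nothing available bears on why the outcome is the same in the two pairs.

Still open, as far as these compounds go, is whether the same holds when a group of a different kind, such as a carboxylic acid or a primary amide, stands on that saturated chain carbon, or when a longer chain carries the two amine nitrogens. Also open, from the compounds shown here alone, is whether a third core, for instance one carrying a nitrile in place of the trifluoromethyl groups, would repeat the outcome of these two pairs.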